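The source may report more compounds than this note shows. Statements on the series, on what has been measured and on what is new or still open speak of the compounds shown alone.

Compound 2 `CCC1(CCCCN2CCN(c3ccccc3)CC2)C(=O)Nc2ccccc21` and compound 1 `CCC1(CCCCN2CCN(c3ccc(Cl)cc3)CC2)C(=O)Nc2ccccc21` share a core and differ only in the ring that hangs from the piperazine. In an assay on CHO cells for displacement of a labelled ligand from 5-hydroxytryptamine receptor 7 (Homo sapiens) (on this read-out lower numbers stand for stronger inhibition and higher numbers for weaker inhibition), compound 1 gives 0.38 nM; 0.38 nM (2 entries), and in this assay compound 2 gives 2.07 nM; these are the only numbers shown for the pair, and compound 2 has one further entry without a single number. Compound 2 therefore stands at the higher, weaker end of the two values shown.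

Compound 3 `CCC1(CCCCN2CCN(c3ccc(OC)cc3)CC2)C(=O)Nc2ccccc21` is the next member of this set. The change from compound 2 to compound 3 is methoxy in place of hydrogen on an aromatic carbon, para to a large group. For the measured compounds named here, no measured step covers this particular exchange, so the expectation rests on the two values shown and on the nature of the change.

The step from compound 2 to compound 3 in this assay is expected to be small, toward lower numbers, and probably within the scatter, giving a 1.7-fold lower number from compound 2 to compound 3 (0.24 log units; within the scatter). Compound 3 is expected to give 1.2 nM in this assay, with a range from 0.4 nM to 4 nM.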

Compound 3, inhibition constant: 25.4 nM
The estimate for compound 3 lay 21-fold (1.33 log units) below the measured number; measured number outside the range, above it.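

In this assay the outer ring on the piperazine proves sensitive to what is placed on it: methoxy in place of hydrogen, para to a large group, gives a 12-fold higher number from compound 2 to compound 3 (1.09 log units; beyond the scatter) and so moves the number in the weaker direction. For the compounds shown here, this is the first sign that the position does not accept every group alike, since compound 1, which carries chlorine in the same place, gives 0.38 nM; 0.38 nM (2 entries) and compound 3 gives 25.4 nM in the same assay. Nothing available here explains why methoxy has this effect, so the result records the size of the change and not its cause.

The compounds shown leave open whether a hydroxyl, a methyl or a fluorine at this position would stay close to compound 2 or shift the number as far as methoxy does. They also leave open whether methoxy on another carbon of the same ring, or a longer ethoxy group at this position, would give a step of similar size.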